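Removing a chloro from the urea aryl of compound 3

This account rests on a few compounds, and the source may have more. Where it says the series, first, only, none or still open, it means among the compounds named here.

Compound 1 `O=C(Nc1cccc(-n2cc(-c3ccncc3)c(-c3cc(O)cc(Cl)c3)n2)c1)Nc1ccc(Cl)c(C(F)(F)F)c1`: -18%
Compound 2 `O=C(Nc1cccc(-n2cc(-c3ccncc3)c(-c3cc(O)cc(Cl)c3)n2)c1)Nc1ccc(Cl)c(Cl)c1`: -27.1%
Compound 3 `COc1cc(Cl)cc(-c2nn(-c3cccc(NC(=O)Nc4ccc(Cl)c(C(F)(F)F)c4)c3)cc2-c2ccncc2)c1`: -9.68%

In a functional assay on MOLT-4 cells (Homo sapiens) for inhibition, read by sulforhodamine B assay, with a stated time of 48 h, tested at 10 uM (a lower number here means a stronger effect, a higher number a weaker effect of the compound at the concentration tested), compound 3 holds the highest of the three numbers; its nearest neighbour is compound 1, a step within the scatter, while compound 2 lies further off, beyond it. Compound 4 `COc1cc(Cl)cc(-c2nn(-c3cccc(NC(=O)Nc4cccc(C(F)(F)F)c4)c3)cc2-c2ccncc2)c1` differs from compound 3 only by hydrogen in place of chloro on an aromatic carbon, so that 4-chloro-3-(trifluoromethyl)phenyl becomes 3-(trifluoromethyl)phenyl. Among the measured compounds shown here, no measured step removes a chloro there; the only change on that ring, a number 9.1 percentage points lower from compound 1 to compound 2 (within the scatter), stayed within the scatter, as did a number 8.3 percentage points higher from compound 1 to compound 3 (within the scatter). A step of similar size is therefore expected, a number 1.7 percentage points higher from compound 3 to compound 4 (within the scatter), with no movement beyond the scatter. Compound 4 is expected to give -8%, between -30% and 12%.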

Compound 4, a percentage reported as activity, at one concentration (the size of the read-out at that concentration, not a potency): -9.16%
The estimate for compound 4 lay 1.2 percentage points above the measured number; the range from low to high includes it.
By their numbers in this assay, from the lowest: compounds 2, 1, 3 and 4 (each within the scatter of the next, the first and the last beyond it).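

Among the compounds shown here, this is the first test of the chloro para to a large group and ortho to a trifluoromethyl group: in this assay, replacing it with hydrogen gives a number 0.5 percentage points higher from compound 3 to compound 4 (within the scatter), so the two compounds cannot be told apart. In the methoxy series, the read-out at this concentration therefore does not depend on that chloro. Nothing shown here offers an explanation for this result.

Going by these compounds, whether the same replacement would read alike with the hydroxy group of compound 1 remains open. So does the effect of an amine or a carboxylic acid at this position.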